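The source may report more compounds than this note shows. Statements on the series, on what has been measured and on what is new or still open speak of the compounds shown alone.

Measured in an ADME assay on HepG2 cells (Homo sapiens) for cytotoxicity; a lower number here means that less compound is needed, a higher number that more compound is needed for the effect:
Compound 1 `Cc1ccc(S(=O)(=O)N[C@@H](CC(=O)NC(C)(C)C)C(=O)NCCNC(=O)c2c(O)cccc2F)cc1`: > 11000 nM
Compound 2 `Cc1ccc(S(=O)(=O)N[C@@H](CC(=O)NC(C)(C)C)C(=O)NCCNC(=O)c2ccccc2F)cc1`: > 11000 nM
Compound 3 `Cc1ccc(S(=O)(=O)N[C@@H](CC(=O)NC(C)(C)C)C(=O)NCCNC(=O)c2ccccc2Cl)cc1`: > 11000 nM

All three entries are limits, not numbers. In this assay compound 3 reports > 11000 nM, which is a limit. It therefore has no rank among the three, and the evidence is uniform: the limit of > 11000 nM in this assay, at which 3 of the 3 values shown sit.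

The next compound, compound 4 `Cc1ccc(S(=O)(=O)N[C@@H](CC(=O)NC(C)(C)C)C(=O)NCCNC(=O)c2cccc(F)c2)cc1`, carries 3-fluorophenyl in place of 2-chlorophenyl on a carbonyl carbon.

Going by the values given here, three measured steps bear on this change: a step that the two limits leave unreadable from compound 2 to compound 3, a step that the two limits leave unreadable from compound 1 to compound 2 and a step that the two limits leave unreadable from compound 1 to compound 3. None of them has a readable size, so they give no direction for the new step. All that can be carried forward is that each of compounds 1, 2 and 3 sits at the same limit. No step beyond the usual scatter is expected, and compound 4 is expected to stay at that limit too. The expected step is a step that the limit leaves unreadable from compound 3 to compound 4. The estimated value for compound 4 is 12000 nM, with an expected range from 9000 nM to 20000 nM.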

Compound 4, half-maximal effective concentration: > 11000 nM
Compound 4: no number, only a limit (the forecaster's own chance of this, stated with the estimate: 90%); the middle value is on the limit's open side.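

In this assay compound 4 gives > 11000 nM, which is a limit. Its steps to compounds 1, 2 and 3 cannot be read, and the evidence stays uniform: the limit of > 11000 nM in this assay, at which 4 of the 4 values shown sit.

The compounds shown leave open whether any change on the carbonyl carbon alters this read-out at all.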